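A few compounds are considered here, and "the series" means these few. Any claim that something is new, unique, unknown or untested is made for them only; others in the source may bear on it.

Among the measured compounds shown here, compound 1 `CC(C)[C@H](NC(=O)COc1cccc2ccccc12)C(=O)N[C@@H](CC(=O)O)C(=O)CSc1nnnn1-c1ccccc1` is the only compound with a definite number: in a functional assay on Jurkat cells (Homo sapiens) for inhibition (a lower number here means a stronger inhibitor, a higher number a weaker inhibitor), compound 1 gives 153000 nM. Compound 2 `CC(C)[C@H](NC(=O)COc1cccc2ccccc12)C(=O)N[C@@H](CC(=O)O)C(=O)CSc1nc2ccccc2o1` gives > 200000 nM in this assay, which is a limit of the assay rather than a number. The step of an at least 1.3-fold higher number from compound 1 to compound 2 (0.11 log units; that floor lies within the scatter) is therefore known only as a floor, and the limit of > 200000 nM in this assay, at which 1 of the 2 values shown sits, describes that limit. Compound 3 `CC(C)[C@H](NC(=O)COc1cccc2ccccc12)C(=O)N[C@@H](CC(=O)O)C(=O)COc1ncnc2ccccc12` differs from compound 1 by (quinazolin-4-yl)oxy in place of (1-phenyl-1H-tetrazol-5-yl)sulfanyl on a saturated chain carbon bound to a carbonyl carbon. For the measured compounds named here, no measured step covers an exchange of the sulfanyl linkage itself, so only the direction seen in the one step from compound 1 to compound 2 is available. Compound 3 is expected at 200000 nM, between 60000 nM and 600000 nM, an estimated step of a 1.3-fold higher number from compound 1 to compound 3 (0.12 log units; within the scatter).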

Compound 3, half-maximal inhibitory concentration: > 200000 nM
Compound 3 ended at the assay's limit (the forecaster's own chance of this, stated with the estimate: 50%); the middle value lies on the limit itself.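

The exchange of (1-phenyl-1H-tetrazol-5-yl)sulfanyl for (quinazolin-4-yl)oxy on this saturated chain carbon gives an at least 1.3-fold higher number from compound 1 to compound 3 (0.11 log units; that floor lies within the scatter), so this step, like the earlier one, is known only as a floor. It extends the picture from a sulfur-linked group to an oxygen-linked one, and compound 3 also reaches the limit of this assay: the limit of > 200000 nM in this assay, at which 2 of the 3 values shown sit. The step between compound 2 and compound 3 cannot be read, since both values are limits.

Going by these compounds, how far either limit lies from a true number stays open. So does how an amine or a fluorine atom at this place would read.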